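Adding a Second Fluorine to an Aminothiophene Piperazine

The source may hold more compounds than are shown below. What is called first, only, known or untested is meant among the compounds shown, and "the series" means these compounds.

Measured so far:
compound 1, `Nc1scc(CN2CCN(c3ccc([N+](=O)[O-])cc3)CC2)c1C(=O)c1ccc(Cl)cc1`, -13%
compound 2, `Nc1scc(CN2CCN(c3ccccc3F)CC2)c1C(=O)c1ccc(Cl)cc1`, -1%

Both compounds were tested in a functional assay on CHO cells with adenosine receptor A1 (Homo sapiens) as the target, read by cAMP accumulation and immunoassay, with a stated time of 6 min, tested at 0.1 uM; on this read-out higher numbers stand for a weaker effect at the one concentration tested and lower numbers for a stronger effect. On the numbers shown, compound 2 stands highest of the two, with compound 1 the only neighbour, and the step of a number 12 percentage points higher from compound 1 to compound 2 (beyond the scatter).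

The next compound, compound 3, `Nc1scc(CN2CCN(c3c(F)cccc3F)CC2)c1C(=O)c1ccc(Cl)cc1`, differs from compound 2 in one place: fluoro in place of hydrogen on an aromatic carbon. Put a bond further out, the 2-fluorophenyl becomes a 2,6-difluorophenyl.

Going by the values given here, no measured step bears directly on this change. Among the compounds with values here, the only step measured, from compound 1 to compound 2, swaps one whole aryl group for another, and is modest in size. There is therefore no shown evidence that one more fluoro on the same ring should move the read-out beyond the scatter, and the expected step of a number 3 percentage points higher from compound 2 to compound 3 (within the scatter) is small. Compound 3 is thus estimated to give 2% in this assay, within a range from -12% to 16%.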

Compound 3, a percentage reported as activity, at one concentration (the size of the read-out at that concentration, not a potency): -23%
The estimate for compound 3 lay 25 percentage points above the measured number; measured number outside the range, below it.
By their numbers in this assay, from the lowest: compounds 3 and 1 (each within the scatter of the next); then compound 2.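

In this assay the ring position ortho to a large group proves responsive: one added fluoro gives a number 22 percentage points lower from compound 2 to compound 3 (beyond the scatter) and so moves the read-out towards a stronger effect, which the earlier swap of one whole aryl group for another could not have shown. The comparison with the nitro compound gives a number 10 percentage points lower from compound 1 to compound 3 (within the scatter) and so leaves the 2,6-difluorophenyl and 4-nitrophenyl compounds indistinguishable here, while the 2-fluorophenyl of compound 2 alone stands apart from both, so adding fluoro to this ring does not simply carry the earlier step further. Nothing available here explains why a second fluoro has this result.

The compounds shown leave open whether the shift belongs to fluoro itself or would also follow from a chloro, methyl or methoxy group at the same place on the ring. They also leave open how these compounds would compare across a range of concentrations, since each reading here comes from a single concentration and is not a measure of potency.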